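The source may hold more compounds than are shown below. What is called first, only, known or untested is meant among the compounds shown, and "the series" means these compounds.

Measured so far in a functional assay on MCF7 cells (Homo sapiens) for antiproliferative activity; on this read-out higher numbers stand for weaker inhibition and lower numbers for stronger inhibition:
compound 1 `CCCCn1c(Cc2c(Br)c(OC)c(OC)c(OC)c2Br)nc2c(N)ncnc21` gives 30200 nM
compound 2 `CC/C=C\Cn1c(Cc2cc(OC)c(OC)c(OC)c2)nc2c(N)ncnc21` gives 64600 nM
compound 3 `CC[C@H](C)Cn1c(Cc2cc(OC)c(OC)c(OC)c2)nc2c(N)nc(F)nc21` gives 43700 nM

Compound 2 stands at the highest of the three numbers. Its nearest neighbour is compound 3, whose number sits within the usual scatter of repeated measurements, so the two cannot be told apart on this read-out; compound 1 lies beyond that scatter, at the lower and therefore stronger end. Going by the values given here, none of the three differs from another in only one place, so no single step between measured compounds can be read off.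

Compound 4 `COc1cc(Cc2nc3c(N)ncnc3n2CC2(C)CC2)cc(OC)c1OC` has not yet been measured. It differs from compound 2 in one place: 1-methylcyclopropyl in place of but-1-en-1-yl on a saturated chain carbon bound to an aromatic nitrogen. The two are built from the same atoms, joined differently, and the exchange happens on a saturated chain carbon bound to an aromatic nitrogen.

Among the compounds with values here, with no measured step of this kind to lean on, the expectation rests only on the three numbers in hand, which lie close together. A change of this size on the chain is expected to move this assay little, and not clearly beyond the scatter in either direction. Compound 4 is therefore expected to give about 45000 nM, within 15000 nM to 130000 nM. The expected step of a 1.4-fold lower number from compound 2 to compound 4 (0.16 log units; within the scatter) is a small one, inside the usual scatter.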

Compound 4, half-maximal inhibitory concentration: 112000 nM
Compound 4: the middle estimate sits 2.5-fold (0.40 log units) below what was measured, and the stated range covers the measured number.
By their numbers in this assay, from the lowest: compounds 1, 3, 2 and 4 (each within the scatter of the next, the first and the last beyond it).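

Going by these compounds alone, this is the first comparison in the set in which only one place changes, so it gives the first direct reading at the saturated chain carbon bound to an aromatic nitrogen. In this assay, putting 1-methylcyclopropyl in place of but-1-en-1-yl gives a 1.7-fold higher number from compound 2 to compound 4 (0.24 log units; within the scatter) and so stays inside the normal variation between repeat measurements. An open chain with a double bond and a group with a three-membered ring, built from the same atoms but joined differently, therefore cannot be told apart on this read-out, and no supporting measurement is available to explain the result.

A single pair cannot show whether the same exchange would read the same way with the bromine atoms of compound 1 or the fluorine atom of compound 3 on the shared core. Going by these compounds, it also remains open how this position responds to something other than a plain hydrocarbon group, such as a chain ending in an amine or a carboxylic acid, or to a much longer chain such as decyl.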